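This account rests on a few compounds, and the source may have more. Where it says the series, first, only, none or still open, it means among the compounds named here.

The series opens with compound 1 `O=C(CN(c1ncnc2c1ncn2C1CCCCO1)C1CC1)N[C@@H](CCC(=O)OCc1ccccc1)C(=O)OCc1ccccc1`, and in a functional assay on the whole organism (Tail, strain ICR) with Mus musculus as the target, in the tail flick test, with a stated time of 90 min, at a dose of 25 umol/kg by the oral route (a higher number here means a stronger effect of the compound at the dose given, a lower number a weaker effect), compound 1 gives 25.2%. That is the lowest of the three numbers recorded so far. Compound 2 `C[C@@H](O)[C@H](NC(=O)CN(c1nc(Cl)nc2[nH]cnc12)C1CC1)C(=O)OCc1ccccc1` gives 29.9%, which sits within the scatter of compound 1. Compound 3 `O=C(CN(c1nc(Cl)nc2[nH]cnc12)C1CC1)N[C@@H](CCC(=O)OCc1ccccc1)C(=O)OCc1ccccc1` gives 50%, a number that lies beyond the scatter above compound 1; compound 3 carries the same side chain as compound 1 but shares its core with compound 2 rather than with compound 1.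

The step now followed leads from compound 1 to compound 4 `C[C@@H](O)[C@H](NC(=O)CN(c1ncnc2c1ncn2C1CCCCO1)C1CC1)C(=O)OCc1ccccc1`. The change is 1-hydroxyethyl in place of 2-(benzyloxycarbonyl)ethyl on a saturated chain carbon bound to an amide-type nitrogen and a carbonyl carbon. Within the data shown here, one measured step bears directly on it, in the opposite direction: a number 20.1 percentage points higher from compound 2 to compound 3 (beyond the scatter). Since compound 4 reverses that exchange on the core of compound 1, a drop of roughly the same size is expected in this assay. Because compound 1 already stands at 25.2%, such a drop is expected to leave compound 4 with a still weaker number in this assay.

Compound 4 is therefore expected to fall by a number 15.2 percentage points lower from compound 1 to compound 4 (beyond the scatter). For compound 4 the estimate in this assay is 10%, with a range from 0% to 25%.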

Compound 4, a percentage reported as activity, at one dose (the size of the read-out at that dose, not a potency): 23.4%
The estimate for compound 4 lay 13.4 percentage points below the measured number; the range from low to high includes it.
By their numbers in this assay, from the lowest: compounds 4, 1 and 2 (each within the scatter of the next); then compound 3.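

On the core of compound 1, 1-hydroxyethyl in place of 2-(benzyloxycarbonyl)ethyl on a saturated chain carbon bound to an amide-type nitrogen and a carbonyl carbon gives no readable change in this assay, with a number 1.8 percentage points lower from compound 1 to compound 4 (within the scatter). The earlier compounds shown here showed this exchange only on the core shared by compound 2 and compound 3, where it moved the number beyond the scatter; on the core of compound 1, a group of 12 heavy atoms with an aromatic ring and a group of 3 heavy atoms with no ring give values within the scatter of each other. The weight of this position in this assay therefore does not carry over from one core to the other, and the two steps for the same change differ clearly: the same change on two cores in this assay, a number 20.1 percentage points higher (beyond the scatter) from compound 2 to compound 3 and a number 1.8 percentage points higher (within the scatter) from compound 4 to compound 1, 18.3 percentage points apart, beyond the scatter of two such steps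

The compounds shown leave open which of the differences between the two cores goes with this gap, since only these two cores carry the exchange. They also leave open how a carboxylic acid, an amine or a longer chain on this saturated chain carbon would read on either core.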